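The source may report more compounds than this note shows. Statements on the series, on what has been measured and on what is new or still open speak of the compounds shown alone.

Measured so far:
compound 1, `COc1ccccc1-c1cc(CN(C)C)ccc1Cl`, in an assay on isolated protein for binding affinity to 5-hydroxytryptamine receptor 3A (Homo sapiens) (a lower number here means a stronger inhibitor, a higher number a weaker inhibitor), gives 1000 nM
compound 2, `CCN(CC)Cc1ccc(Cl)c(-c2ccccc2OC)c1`, in this assay gives > 10000 nM

The value of compound 2 is a limit of the assay, not a number. Compound 2 therefore sits at the limit of > 10000 nM in this assay, at which 1 of the 2 values shown sits, so its true affinity is known only to be weaker than that mark. Going by the values given here, the one measured step, an at least 10-fold higher number from compound 1 to compound 2 (1.00 log units; beyond the scatter), shows that enlarging the amine from dimethylamino to diethylamino weakened binding clearly beyond the scatter.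

Compound 3, `CCCNCc1ccc(Cl)c(-c2ccccc2OC)c1`, has not been measured. It differs from compound 2 by propylamino in place of diethylamino on a saturated chain carbon bound to an aromatic carbon. Among the compounds with values here, no measured step covers this exact change; only the step from compound 1 to compound 2 bears on it, and it points to the smaller amine being the stronger binder. Compound 2 shows only a limit, and the starting point is uncertain. The step to compound 3 is expected to be an at least 2.0-fold lower number from compound 2 to compound 3 (0.30 log units; that floor lies within the scatter), in the direction of stronger binding. Compound 3 is therefore estimated at 5000 nM in this assay, within a range from 1000 nM to 20000 nM.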

Compound 3, inhibition constant: > 10000 nM
Compound 3: only a limit was reported; the forecaster's own chance of this, stated with the estimate: 45%; middle value at least 2.0-fold (0.30 log units) from the limit.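

The value of compound 3 in this assay, > 10000 nM, is a limit of the assay and not a number. The change from dimethylamino to propylamino on a saturated chain carbon bound to an aromatic carbon gives an at least 10-fold higher number from compound 1 to compound 3 (1.00 log units; beyond the scatter), so the loss of binding seen with diethylamino is not confined to that one group: propylamino, which carries a hydrogen-bond donor that diethylamino lacks, also falls well short of dimethylamino. The step between compound 2 and compound 3 cannot be read, and the two compounds cannot be put in order, because both sit at the same mark: the limit of > 10000 nM in this assay, at which 2 of the 3 values shown sit.

As far as these compounds go, how far the true affinities of compound 2 and compound 3 lie past that limit stays open, so it cannot be told whether the hydrogen-bond donor of propylamino makes any difference to binding. Also open, from the compounds shown here alone, is how a smaller amine such as methylamino, or a ring amine such as pyrrolidine, would compare with dimethylamino at this place in this assay.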